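Diarylamine amides: branching the acyl chain of compound 2

The source may report more compounds than this note shows. Statements on the series, on what has been measured and on what is new or still open speak of the compounds shown alone.

Measured compounds:
- compound 1, `COc1cccc(Nc2ccc(NC(=O)C(C)C)cc2)c1`: 84 nM
- compound 2, `CCC(=O)Nc1ccc(N(C)c2cccc(OC)c2)cc1`: 0.17 nM

In an assay on isolated protein for binding affinity to melatonin receptor type 1B (Homo sapiens) (a lower number here means a stronger inhibitor, a higher number a weaker inhibitor), compound 2 gives the lowest of the two numbers recorded; compound 1 gives the higher number, and the gap between them is beyond the scatter. The two compounds differ in more than one place, so their values are only compared as they stand.

Compound 3, `COc1cccc(N(C)c2ccc(NC(=O)C(C)C)cc2)c1`, is not yet measured. Relative to compound 2 the change is methyl in place of hydrogen on a saturated chain carbon bound to a carbonyl carbon and a saturated chain carbon. Within the data shown here, no measured pair shows this change on its own, so its size is unknown here. A modest loss of affinity is expected, within or just beyond the scatter, giving an estimated step of a 2.9-fold higher number from compound 2 to compound 3 (0.47 log units; beyond the scatter) in this assay. Compound 3 is thus expected at about 0.5 nM, with a range of 0.1 nM to 3 nM.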

Compound 3, inhibition constant: 5.5 nM
For compound 3 the middle estimate is 11-fold (1.04 log units) below the measured one; measured number above the stated range.
By their numbers in this assay, from the lowest: compound 2; then compound 3; then compound 1.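

In this assay, methyl in place of hydrogen on a saturated chain carbon bound to a carbonyl carbon and a saturated chain carbon gives a 32-fold higher number from compound 2 to compound 3 (1.51 log units; beyond the scatter), so ethyl to isopropyl at this position is a large loss rather than a modest one. With the isopropylcarbonyl group kept, methyl in place of hydrogen on a nitrogen on an aromatic ring gives a 15-fold lower number from compound 1 to compound 3 (1.18 log units; beyond the scatter), so compound 3 shows that this second methyl recovers much of the affinity without reaching the value of compound 2. Nothing available explains the size of either step.

From the compounds shown here alone, it remains open whether a longer chain such as butanoyl or a cyclopropylcarbonyl group would follow the isopropylcarbonyl result. Also open, going by these compounds, is whether an ethyl group on that nitrogen would match the methyl.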